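Fluoro on the phenoxy ring of compound 3

The compounds below may be only part of what the source reports. "The series", "measured", "known", "first", "only" and "open" are said of these compounds alone.

Values below come from a functional assay for inhibition, with Homo sapiens as the target; on this read-out lower numbers stand for tighter binding and higher numbers for weaker binding

compound 1 `O=C(O)CC/C=C\CC1COC(c2ccsc2)OC1c1cccnc1` gives 1580 nM
compound 2 `O=C(O)CC/C=C\CC1COC(c2ccc3ccccc3c2)OC1c1cccnc1` gives 1780 nM
compound 3 `CC(C)(Oc1ccccc1)C1OCC(C/C=C\CCC(=O)O)C(c2cccnc2)O1` gives 75.9 nM

Compound 3 has the lowest number of the three, with compound 1 and compound 2 both beyond the scatter from it. The next structure is compound 4 (`CC(C)(Oc1ccc(F)cc1)C1OCC(C/C=C\CCC(=O)O)C(c2cccnc2)O1`), and the change is fluoro in place of hydrogen on an aromatic carbon which reads phenoxy to 4-fluorophenoxy.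

Going by the values given here, no measured step tests a change of this kind. Two steps exchange the whole group and are large: a 21-fold lower number from compound 1 to compound 3 (1.32 log units; beyond the scatter) and a 23-fold lower number from compound 2 to compound 3 (1.37 log units; beyond the scatter) are the evidence that this group matters. The third, a 1.1-fold higher number from compound 1 to compound 2 (0.05 log units; within the scatter) shows that one large exchange can also leave the number unmoved. Among the compounds with values here, all three are far bigger changes in structure than a single fluoro in place of hydrogen, so they give no direction for this step.

The expected result is a 1.1-fold lower number from compound 3 to compound 4 (0.04 log units; within the scatter) with no shift beyond the scatter anticipated in this assay in either direction. For compound 4 the estimate is 70 nM with an expected range from 30 nM to 170 nM for repeat measurements.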

Compound 4, dissociation constant: 120 nM
Compound 4: the middle estimate sits 1.7-fold (0.23 log units) below what was measured, within the range that was stated.
By their numbers in this assay, from the lowest: compounds 3 and 4 (each within the scatter of the next); then compounds 1 and 2 (each within the scatter of the next).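

In this assay, going by these compounds alone, the first single-atom change, fluoro in place of hydrogen on an aromatic carbon para to a large group, gives a 1.6-fold higher number from compound 3 to compound 4 (0.20 log units; within the scatter) and so separates compound 4 from compound 3 by no more than the usual scatter. The earlier steps shown here exchanged whole groups, whereas this one shows that the phenoxy ring of compound 3 accepts a substituent at this position, with 4-fluorophenoxy leaving the read-out effectively unmoved. No data at hand explain this result.

As far as these compounds go, whether chloro, methoxy or an amine on the same carbon would also stay within the scatter of compound 3 remains open, as does the outcome of fluoro on the other carbons of this ring. Also open, from the compounds shown here alone, is whether the two methyl groups and the ether oxygen that link this ring to the core are needed.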